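Changing the Amine on the Thiocarbonyl Carbon

A few compounds are considered here, and "the series" means these few. Any claim that something is new, unique, unknown or untested is made for them only; others in the source may bear on it.

Measured so far:
compound 1 `Nc1ccccc1NC(=O)c1ccc(CSC(=S)N2CCCc3ccccc32)cc1`: 26.1%
compound 2 `Cc1ccc(N2CCN(C(=S)SCc3ccc(C(=O)Nc4ccccc4N)cc3)CC2)cc1`: 25.3%

Of the compounds shown here, two have been measured in a functional assay on HeLa cells (Homo sapiens) for antiproliferative activity, read by CCK-8 assay, with a stated time of 72 h, tested at 2 uM; a higher number here means a stronger effect of the compound at the concentration tested, a lower number a weaker effect. Compound 1 gives 26.1%, and compound 2 gives 25.3%. Compound 1 holds the higher of the two numbers, but the nearest number, that of compound 2, lies within the usual scatter of this kind of measurement, so the two cannot be told apart and no order between them is claimed.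

Compound 3 `CN(Cc1cccnc1)C(=S)SCc1ccc(C(=O)Nc2ccccc2N)cc1` has not been measured. It differs from compound 1 in a single place: methyl((pyridin-3-yl)methyl)amino in place of 1,2,3,4-tetrahydroquinolin-1-yl on a thiocarbonyl carbon. The rest of the molecule, the shared core of compound 1, is unchanged.

For the measured compounds named here, no step between two measured compounds is available to show how large an effect a change at this position has. Going by the values given here, the only guide is that the two measured compounds, which carry different groups on the thiocarbonyl carbon, give numbers within the scatter of each other. The expectation for compound 3 is therefore a step of a number 2.1 percentage points lower from compound 1 to compound 3 (within the scatter), estimated to stay within the scatter. Compound 3 is expected to give about 24% in this assay , with a range from 10% to 40%.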

Compound 3, a percentage reported as inhibition, at one concentration (the size of the read-out at that concentration, not a potency): 16.4%
For compound 3 the middle estimate is 7.6 percentage points above the measured one; low and high end bracket the measured number.
By their numbers in this assay, from the lowest: compounds 3, 2 and 1 (each within the scatter of the next).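

The thiocarbonyl carbon now has its first step between two measured compounds, a number 9.7 percentage points lower from compound 1 to compound 3 (within the scatter), in this assay. This is a large change in structure: 1,2,3,4-tetrahydroquinolin-1-yl, with a six-membered non-aromatic ring and an aromatic ring of carbon only, gives way to methyl((pyridin-3-yl)methyl)amino, with a single six-membered aromatic ring that holds a hetero atom and brings one hydrogen-bond acceptor, yet the two compounds still cannot be told apart, so this swap shows no real effect on the read-out. No measured property bears on this result, so nothing can be said about what lies behind the step.

As far as these compounds go, whether any group on this carbon can shift the number beyond the scatter remains open, for example a small open-chain dimethylamino group or a morpholin-4-yl ring, which would test the position with far less bulk or with a ring oxygen. The read-out also comes from a single concentration, so it leaves open how the potencies of compound 1 and compound 3 compare.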